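Thiourea substituent variation on the shared core

The source may hold more compounds than are shown below. What is called first, only, known or untested is meant among the compounds shown, and "the series" means these compounds.

Of the compounds shown here, two carry numbers so far. In a functional assay on MDA-MB-231 cells (Homo sapiens) for inhibition, read by MTT assay, with a stated time of 48 h (a higher number here means a weaker inhibitor of growth, a lower number a stronger inhibitor of growth), compound 1 `Cc1cccc(Nc2ncnc3ccc(NC(=S)NCc4ccccc4)cc23)c1` gives 19500 nM. In this assay compound 2 `Oc1ccc(NC(=S)Nc2ccc3ncnc(Nc4cccc(Br)c4)c3c2)cc1` gives 17300 nM, the lowest of the two numbers, with its gap to compound 1 within the scatter. Compound 3 `S=C(NCc1ccc(Cl)cc1)Nc1ccc2ncnc(Nc3cccc(Br)c3)c2c1` is not yet measured and differs from compound 2 by 4-chlorobenzyl in place of 4-hydroxyphenyl on an amide-type nitrogen. Among the compounds with values here, no measured pair covers this change; the only guide is that compound 1 and compound 2 sit within the scatter of each other. The step from compound 2 to compound 3 is expected to be a 1.1-fold lower number from compound 2 to compound 3 (0.03 log units; within the scatter), nothing beyond the scatter. Compound 3 is therefore estimated at 16000 nM, within 7000 nM to 40000 nM.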

Compound 3, concentration for 50% growth inhibition: 23000 nM
Beside the measured number, compound 3's estimate is 1.4-fold (0.16 log units) below it; measured number inside the range.
By their numbers in this assay, from the lowest: compounds 2, 1 and 3 (each within the scatter of the next).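

In this assay the change from 4-hydroxyphenyl to 4-chlorobenzyl on the amide-type nitrogen gives a 1.3-fold higher number from compound 2 to compound 3 (0.12 log units; within the scatter) as a direct one-place comparison that compound 1 and compound 2 could not provide. At this position, the loss of the hydrogen-bond donor and acceptor counted on 4-hydroxyphenyl comes with no step beyond the scatter. No supporting data bear on this result. From the compounds shown here alone, whether an amine, a carboxylic acid or a longer chain at this nitrogen would give a step beyond the scatter remains open. Also open, going by these compounds, is how the same change reads on the core of compound 1.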